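Adding a Trifluoromethyl Group to a Weak Melanoma Growth Inhibitor

This account rests on a few compounds, and the source may have more. Where it says the series, first, only, none or still open, it means among the compounds named here.

Compound 1 `O=C(Nc1cccc(-n2cc(-c3ccncc3)c(-c3ccc(Cl)c(O)c3)n2)c1)Nc1cccc(C(F)(F)F)c1` is the weaker of the two compounds measured here. In a functional assay on SK-MEL-2 cells (Homo sapiens) for inhibition, read by sulforhodamine B assay, with a stated time of 48 h (a higher number here means a weaker inhibitor of growth, a lower number a stronger inhibitor of growth), compound 1 gives 10800 nM, while compound 2 `O=C(Nc1cccc(-n2cc(-c3ccncc3)c(-c3ccc(Cl)c(O)c3)n2)c1)Nc1ccc(Cl)c(Cl)c1` gives 2640 nM. Within the data shown here, the only measured step, a 4.1-fold lower number from compound 1 to compound 2 (0.61 log units; beyond the scatter), replaces one substituted phenyl group on the urea nitrogen with another, and it shows that changing the substituents on that ring can move the number by a modest but real amount.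

Compound 3 `O=C(Nc1cccc(-n2cc(-c3ccncc3)c(-c3ccc(Cl)c(O)c3)n2)c1)Nc1cc(C(F)(F)F)cc(C(F)(F)F)c1` keeps everything in compound 1 except for one change: trifluoromethyl in place of hydrogen on an aromatic carbon. Among the measured compounds shown here, this change sits on the same phenyl ring that was altered in the step from compound 1 to compound 2, so that step is the only guide available, though it is not the same change, and the direction it points is only suggestive. A further substituent on this ring is therefore expected to lower the number by a modest amount at most, giving an estimated step of a 2.0-fold lower number from compound 1 to compound 3 (0.29 log units; within the scatter). Compound 3 is expected to give about 5500 nM in this assay, with a likely range from 1800 nM to 17000 nM.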

Compound 3, concentration for total growth inhibition: 3030 nM
Compound 3: middle estimate off by 1.8-fold (0.26 log units), on the high side, and the stated range covers the measured number.
By their numbers in this assay, from the lowest: compounds 2 and 3 (each within the scatter of the next); then compound 1.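

In this assay, adding a trifluoromethyl group to an aromatic carbon, meta to the trifluoromethyl group already on the ring, gives a 3.6-fold lower number from compound 1 to compound 3 (0.55 log units; beyond the scatter), a modest change that lies beyond the usual scatter. The earlier step swapped one pattern of ring substituents for another, so it could not show what adding a group alone does; here only a hydrogen leaves, and the number falls rather than rises, so this place on the ring accepts a further trifluoromethyl group without any loss of growth inhibition in these cells. No measurement here bears on why this change lowers the number.

As far as these compounds go, what remains open is whether this gain belongs to trifluoromethyl itself or would also appear with another group at the same place, such as a single fluorine atom, a methoxy group, an amine or a carboxylic acid. With only this one addition shown, it also remains open whether the result depends on the trifluoromethyl group already on the ring, which a compound carrying a lone methoxy group or lone fluorine atom there could help to test.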